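Trading a Pyridine for a Methylphenyl on the Shared Core

The source may hold more compounds than are shown below. What is called first, only, known or untested is meant among the compounds shown, and "the series" means these compounds.

Compound 1 `C(=C/c1nn2c(-c3ccncc3)nnc2s1)\c1ccco1` and compound 2 `c1ccc2c(Cc3nn4c(-c5ccoc5)nnc4s3)cccc2c1` share a fused core and were both tested in an assay for inhibition of histone-lysine N-methyltransferase, H3 lysine-79 specific (Homo sapiens), read by scintillation counting, with stated times of 15 min and 60 min, tested at 25 uM, in the presence of a further agent that is not named here; on this read-out lower numbers stand for a weaker effect and higher numbers for a stronger effect at the one concentration tested. In this assay, among the compounds with values here, compound 1 gives 54%, the higher of the two numbers measured so far, while compound 2 gives 43%, a lower result whose gap to compound 1 lies beyond the usual scatter of repeated runs. Since these two compounds differ in more than one place, their gap cannot be tied to any single change.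

Compound 3 `Cc1cccc(-c2nnc3sc(/C=C/c4ccco4)nn23)c1` has not yet been measured. It differs from compound 1 in one place: 3-methylphenyl in place of pyridin-4-yl on an aromatic carbon. A six-membered aromatic ring with one hetero atom gives way to a six-membered aromatic ring of carbon only, and the hydrogen-bond acceptor of the leaving group is gone. Within the data shown here, no measured pair shows the effect of such a change here, so the expectation rests on compound 1 alone. The expected step is a number 6 percentage points lower from compound 1 to compound 3 (within the scatter), a modest weakening or none beyond the scatter. Compound 3 is therefore estimated to give 48%, with a likely range from 30% to 65%.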

Compound 3, a percentage reported as inhibition, at one concentration (the size of the read-out at that concentration, not a potency): 66.6%
For compound 3 the middle estimate is 18.6 percentage points below the measured one; measured number above the stated range.
By their numbers in this assay, from the lowest: compound 2; then compound 1; then compound 3.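

Within the data shown here, at this position, on an aromatic carbon between two ring nitrogen atoms, the ring does not have to be pyridin-4-yl to keep the effect in this assay: placing 3-methylphenyl there gives a number 12.6 percentage points higher from compound 1 to compound 3 (beyond the scatter) and supplies the first measured step in this small set. The entering ring is of carbon only and its group has no hydrogen-bond acceptor, so for this pair the acceptor of the pyridin-4-yl group is not required for a number of this size, though the read-out reports the effect at one concentration and is not a potency. Nothing measured here explains why the number rises.

The step combines two changes, the loss of the ring nitrogen and the arrival of the methyl group, and this pair cannot divide the rise between them. On these data alone, a plain phenyl ring at this position would begin to separate the two, while a phenyl ring carrying an amine or a carboxylic acid would test how far the position tolerates other groups, and both questions remain open.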